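This account rests on a few compounds, and the source may have more. Where it says the series, first, only, none or still open, it means among the compounds named here.

Among the compounds with values here, in a functional assay on MGC-803 cells (Homo sapiens) for inhibition, read by MTT assay, with a stated time of 48 h (on this read-out higher numbers stand for weaker inhibition and lower numbers for stronger inhibition), compound 1 (`COc1cccc(Nc2nnc(Cl)c(Nc3cc(OC)c(OC)c(OC)c3)n2)c1`) gives 16500 nM and compound 2 (`COc1cc(Nc2nc(Nc3ccc(C)cc3)nnc2Cl)cc(OC)c1OC`) gives 19800 nM, which leaves compound 2 level with the only other measured member of the series. Compound 3 (`COc1cc(Nc2nc(Nc3ccc4c(ccn4C)c3)nnc2Cl)cc(OC)c1OC`) carries 1-methyl-1H-indol-5-yl in place of 4-methylphenyl on a nitrogen on an aromatic ring. Within the data shown here, the one measured step at this place, a 1.2-fold higher number from compound 1 to compound 2 (0.08 log units; within the scatter), lies within the scatter, but it does not involve 1-methyl-1H-indol-5-yl, so it guides this change only loosely. Little movement beyond the scatter is therefore expected in this assay, and no firm direction can be assigned. The expected step is a 1.7-fold lower number from compound 2 to compound 3 (0.22 log units; within the scatter). For compound 3 the estimated value is 12000 nM, with an expected range of 2500 nM to 40000 nM.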

Compound 3, half-maximal inhibitory concentration: 28100 nM
The estimate for compound 3 lay 2.3-fold (0.37 log units) below the measured number; low and high end bracket the measured number.
By their numbers in this assay, from the lowest: compounds 1, 2 and 3 (each within the scatter of the next).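

At this place, on a nitrogen on an aromatic ring, the two-ring 1-methyl-1H-indol-5-yl leaves this assay within the scatter, with a 1.4-fold higher number from compound 2 to compound 3 (0.15 log units; within the scatter) and a 1.7-fold higher number from compound 1 to compound 3 (0.23 log units; within the scatter). Within the data shown here, the three groups now tried here, including a five-membered aromatic ring with a hetero atom for the first time, cannot be told apart by their numbers. No evidence is available to explain this flat result. Still open, from the compounds shown here alone, is whether any group here moves the number beyond the scatter, for example a phenyl ring carrying an aliphatic amine or a carboxylic acid.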